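Aryl groups on the ring nitrogen and cytotoxicity

The compounds below may be only part of what the source reports. "The series", "measured", "known", "first", "only" and "open" are said of these compounds alone.

Measured compounds:
- compound 1 `Nc1ccc(/C=C2\SC(=O)N(Cc3ccc(Cl)cc3)C2=O)cc1`: in a functional assay on L1210 cells (Mus musculus) for cytotoxicity, read by cell counting, with a stated time of 2 days (on this read-out higher numbers stand for weaker inhibition and lower numbers for stronger inhibition), compound 1 gives 37000 nM
- compound 2 `Nc1ccc(/C=C2\SC(=O)N(Cc3ccccc3)C2=O)cc1`: in this assay compound 2 gives 38000 nM
- compound 3 `CN1C(=O)S/C(=C\c2ccc(N)cc2)C1=O`: in this assay compound 3 gives 99000 nM

Compound 3 has the highest number of the three in this assay, so it is the weakest inhibitor here; the nearest is compound 2, and compound 1 lies only slightly further away. The two steps that lead to compound 3 both remove a group from the same place: a 2.7-fold higher number from compound 1 to compound 3 (0.43 log units; beyond the scatter) and a 2.6-fold higher number from compound 2 to compound 3 (0.42 log units; beyond the scatter). Each is a modest rise beyond the scatter, and the two are almost the same size, so the chloro substituent on the aromatic ring made no visible difference (a 1.0-fold higher number from compound 1 to compound 2 (0.01 log units; within the scatter)).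

Compound 4 `Cc1ccc(CN2C(=O)S/C(=C\c3ccc(N)cc3)C2=O)cc1` has not been measured. Its change from compound 3 is 4-methylphenyl in place of hydrogen on a saturated chain carbon bound to an amide-type nitrogen in a ring. This reverses, in kind, the steps just described, since it restores an aromatic ring on that carbon. The expectation in this assay is therefore a modest fall in the number, of about the size seen for compound 1 and compound 2, because a 2.6-fold higher number from compound 2 to compound 3 (0.42 log units; beyond the scatter) and a 2.7-fold higher number from compound 1 to compound 3 (0.43 log units; beyond the scatter) were alike. The estimated step is a 2.7-fold lower number from compound 3 to compound 4 (0.43 log units; beyond the scatter). For compound 4 the estimate in this assay is 37000 nM, with a range from 20000 nM to 70000 nM.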

Compound 4, half-maximal inhibitory concentration: 94000 nM
Compound 4: middle estimate off by 2.5-fold (0.40 log units), on the low side, and the stated range ends below it.
By their numbers in this assay, from the lowest: compounds 1 and 2 (each within the scatter of the next); then compounds 4 and 3 (each within the scatter of the next).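

In this assay, an aromatic ring on a saturated chain carbon bound to an amide-type nitrogen in a ring does not by itself lower the number: 4-methylphenyl in place of hydrogen gives a 1.1-fold lower number from compound 3 to compound 4 (0.02 log units; within the scatter). The small group on that aromatic ring now matters, although the earlier swap of chloro for hydrogen had suggested it did not: methyl in place of hydrogen on an aromatic carbon gives a 2.5-fold higher number from compound 2 to compound 4 (0.39 log units; beyond the scatter), and methyl in place of chloro on an aromatic carbon gives a 2.5-fold higher number from compound 1 to compound 4 (0.40 log units; beyond the scatter). Hydrogen and chloro at this place therefore go with the lower numbers, while methyl goes with the number of compound 3, which has no aromatic ring there at all, although this picture rests on compound 4 alone.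

Going by these compounds, it remains open whether an ethyl group, a methoxy group or an amine on that aromatic carbon would behave like methyl or like chloro. Nothing available here explains why methyl parts from hydrogen and chloro.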